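Working notes on the step from compound 2 to compound 3

This account rests on a few compounds, and the source may have more. Where it says the series, first, only, none or still open, it means among the compounds named here.

Measured so far in a functional assay on LoVo cells (Homo sapiens) for inhibition, read by MTT assay, with a stated time of 48 h; a higher number here means a weaker inhibitor, a lower number a stronger inhibitor
- compound 1 `COc1ccc(N(C)c2nc(C)nc3ccccc23)cc1C(=O)NCC[Se]C#N` gives 561 nM
- compound 2 `COc1ccc(N(C)c2nc(C)nc3ccccc23)cc1C(=O)OCCCC[Se]C#N` gives 1080 nM

Within the data shown here, on these numbers compound 2 cannot be separated from compound 1, its only measured neighbour. Among the measured compounds shown here, the single step between them is a 1.9-fold higher number from compound 1 to compound 2 (0.28 log units; within the scatter) and it sets the scale for what follows.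

Compound 3 `COc1ccc(N(C)c2nc(C)nc3ccccc23)cc1OCC[Se]C#N` has not yet been measured. Its change from compound 2 is a group of 6 heavy atoms (3 carbon, 1 nitrogen, 1 oxygen, 1 selenium; no ring) in place of a group of 10 heavy atoms (6 carbon, 1 nitrogen, 2 oxygen, 1 selenium; no ring), on an aromatic carbon and the site is ortho to a methoxy group and meta to a large group.

For the measured compounds named here, only one measured step bears on this change, the one already given. That step replaced a group on a carbonyl carbon, whereas here the carbonyl leaves with the group, so it is a weak guide. Going by the values given here, no measured compound carries such a chain directly on an aromatic carbon. A clear direction therefore cannot be drawn from the data, and the range has to stay wide.

The expected change in this assay is a 1.4-fold lower number from compound 2 to compound 3 (0.16 log units; within the scatter) and so no step beyond the scatter is expected. For compound 3 the estimated value is 750 nM with an expected range from 280 nM to 2000 nM in this read-out.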

Compound 3, half-maximal inhibitory concentration: 19 nM
For compound 3 the middle estimate is 39-fold (1.60 log units) above the measured one, outside the stated range (below it).
By their numbers in this assay, from the lowest: compound 3; then compounds 1 and 2 (each within the scatter of the next).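

In this assay, the group on the aromatic carbon ortho to a methoxy group has a large influence on the read-out: replacing the carbonyl-containing ester chain with the shorter selenium-bearing chain without a carbonyl gives a 57-fold lower number from compound 2 to compound 3 (1.75 log units; beyond the scatter), and replacing the amide chain gives a 30-fold lower number from compound 1 to compound 3 (1.47 log units; beyond the scatter). The earlier exchange at the carbonyl carbon, a 1.9-fold higher number from compound 1 to compound 2 (0.28 log units; within the scatter), gave no separation, so the first clear difference in the series appears only when the carbonyl leaves with the group, and compound 3 is the strongest inhibitor of the three. Nothing available here accounts for this difference.

The compounds shown leave open whether the step follows from the loss of the carbonyl, the change in the link to the aromatic carbon or the change in chain length, as these differences occur together in each replacement. A longer chain on the same oxygen, an amine in place of that oxygen, or sulfur in place of selenium would help to separate these contributions and test how much of the chain is needed.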